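Chain lengthening on the amide side: antiproliferative notes

This account rests on a few compounds, and the source may have more. Where it says the series, first, only, none or still open, it means among the compounds named here.

Compound 1 `CCCCCCCCCCCCNC(=O)[C@@H]1CSC(c2ccc(OC)c(OC)c2)N1` is the starting point; in a functional assay on cells (Homo sapiens) for antiproliferative activity, read by sulforhodamine B assay, with a stated time of 48 h (on this read-out higher numbers stand for weaker inhibition and lower numbers for stronger inhibition), compound 1 gives 2900 nM. Compound 2 `CCCCCCCCCCCCCCNC(=O)[C@@H]1CSC(c2ccc(OC)c(OC)c2)N1` carries the change ethyl in place of hydrogen on a saturated chain carbon, ten or more bonds along the chain from an amide-type nitrogen and in this assay compound 2 gives 1500 nM, so that a 1.9-fold lower number from compound 1 to compound 2 (0.29 log units; within the scatter). Compound 3 `CCCCCCCCCCCCCCNC(=O)[C@@H]1CSC(c2ccccc2)N1` shares the long amide chain of compound 2 but differs at the ring carbon: a 1.3-fold higher number from compound 2 to compound 3 (0.10 log units; within the scatter); in this assay compound 3 gives 1900 nM. The difference between the core of compound 1 and the core of compound 3 is not broken down here; their two values in this assay lie within the scatter of each other.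

Compound 4 `CCCCCCCCCCCCCCCCNC(=O)[C@@H]1CSC(c2ccccc2)N1` is not yet measured. Within the data shown here, from compound 3 it differs by ethyl in place of hydrogen on a saturated chain carbon, ten or more bonds along the chain from an amide-type nitrogen, which is the same change as the one from compound 1 to compound 2, on the same place of the chain. That earlier change gave a 1.9-fold lower number from compound 1 to compound 2 (0.29 log units; within the scatter), a step within the scatter. Among the measured compounds shown here, with only this single precedent, the step from compound 3 to compound 4 is expected to be of similar size, a 1.5-fold lower number from compound 3 to compound 4 (0.16 log units; within the scatter), because compound 1 to compound 2 read a 1.9-fold lower number from compound 1 to compound 2 (0.29 log units; within the scatter) and nothing suggests the chain carries different weight on the core of compound 3. Compound 4 is therefore estimated at 1300 nM in this assay, with a plausible range from 600 nM to 2800 nM.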

Compound 4, half-maximal inhibitory concentration: 1900 nM
The estimate for compound 4 lay 1.5-fold (0.16 log units) below the measured number; measured number inside the range.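

In this assay, ethyl in place of hydrogen on a saturated chain carbon, ten or more bonds along the chain from an amide-type nitrogen, gives no change at the digits printed from compound 3 to compound 4 (within the scatter). Set beside the earlier step, the readings on the two cores cannot be told apart: the same change on two cores in this assay, a 1.9-fold lower number (0.29 log units; within the scatter) from compound 1 to compound 2 and no change at the digits printed (within the scatter) from compound 3 to compound 4, 1.9-fold (0.29 log units) apart, within the scatter of two such steps. The change therefore carries from the core of compound 1 to the core of compound 3 with no difference that can be resolved in this read-out, but with both steps inside the scatter, this does not show that the change has a real effect on either core, nor that any effect would be the same on both.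

Open, as far as these compounds go, is how a much shorter chain, or an amine or a carboxylic acid on the chain, would read in this assay, and whether any change on the amide side can give a step beyond the scatter. Equally open, from the compounds shown here alone, is what a phenyl carrying a single methoxy group or a fluorine would give on the saturated ring carbon, and whether the ethyl change would still read the same on such a core.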